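A few compounds are considered here, and "the series" means these few. Any claim that something is new, unique, unknown or untested is made for them only; others in the source may bear on it.

Compound 1 `COc1cc(C)cc(-c2c(-c3ccnc(-c4ccc(C(C)=O)cc4)c3)cnn2CC#N)c1` belongs to a small set of three compounds sharing one core, and all three were tested in a functional assay on OVCAR-3 cells (Homo sapiens) for cytotoxicity, read by sulforhodamine B assay, with a stated time of 48 h, tested at 0.001 uM; on this read-out higher numbers stand for a weaker effect at the one concentration tested and lower numbers for a stronger effect. In this assay compound 1 gives 103%, which places it second highest of the three. Compound 3 `Cc1cc(O)cc(-c2nn(CC#N)cc2-c2ccnc(-c3ccc(N(C)C)cc3)c2)c1` gives 105%, a number within the scatter of compound 1, while compound 2 `Cc1cc(O)cc(-c2nn(CC#N)cc2-c2ccnc(-c3ccc(Oc4ccccc4)cc3)c2)c1` gives 92%, which lies beyond the scatter below compound 1.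

Compound 4 `COc1cc(C)cc(-c2c(-c3ccnc(-c4ccc(N(C)C)cc4)c3)cnn2CC#N)c1` has not yet been measured. It differs from compound 1 in one place: dimethylamino in place of acetyl on an aromatic carbon. Among the measured compounds shown here, the only measured step that touches the same entering group is the one in which dimethylamino took the place of phenoxy, a number 13 percentage points higher from compound 2 to compound 3 (beyond the scatter), and that step moved the number modestly upward. For the measured compounds named here, no measured pair covers acetyl leaving, so the bearing of that step is partial.

With every measured number near the level that means little effect, the step of a number 1 percentage points higher from compound 1 to compound 4 (within the scatter) is expected to stay within the scatter, and compound 4 is estimated at 104%, in the range 92% to 116%.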

Compound 4, a percentage reported as activity, at one concentration (the size of the read-out at that concentration, not a potency): 98%
Estimate against measurement, compound 4: 6 percentage points above; low and high end bracket the measured number.
By their numbers in this assay, from the lowest: compounds 2, 4, 1 and 3 (each within the scatter of the next, the first and the last beyond it).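

In this assay, putting dimethylamino in place of acetyl on this aromatic carbon gives a number 5 percentage points lower from compound 1 to compound 4 (within the scatter), so the read-out does not separate these two groups, which match in heavy atoms and hydrogen-bond acceptors. Among the compounds shown here, this is the first direct look at acetyl leaving this place, and it differs from the earlier exchange of phenoxy for dimethylamino, a number 13 percentage points higher from compound 2 to compound 3 (beyond the scatter), which was printed as beyond the scatter. Nothing available here offers an explanation for either step.

The compounds shown leave open whether a carboxylic acid or a longer chain on this aromatic carbon would move the number beyond the scatter. With only one concentration in use, they also leave open whether any of these compounds would give a stronger or weaker effect at another concentration.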